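Pyridin-2-yl for Phenyl on a Triazole-Bearing Core

The source may report more compounds than this note shows. Statements on the series, on what has been measured and on what is new or still open speak of the compounds shown alone.

Compound 1 `Cc1c(O)ccc2c1[C@H](Cn1cc(-c3ccccc3)nn1)[C@@]13CC(=O)[C@@](C)(CC[C@@H]21)C3`: > 20000 nM
Compound 2 `C=C1C[C@]23C[C@@]1(O)CC[C@@H]2c1cccc(C)c1[C@@H]3Cn1cc(-c2ccccc2)nn1`: > 20000 nM

Both results come from a functional assay on SMMC-7721 cells (Homo sapiens) for cytotoxicity, read by MTT assay, with a stated time of 4 days; on this read-out higher numbers stand for weaker inhibition and lower numbers for stronger inhibition. For compound 1 the reading > 20000 nM is a limit of the assay, not a number. For compound 2 the reading > 20000 nM is likewise a limit. So compound 1 stands with every shown value at the limit of > 20000 nM in this assay, at which 2 of the 2 values shown sit. Compound 3 `Cc1c(O)ccc2c1[C@H](Cn1cc(-c3ccccn3)nn1)[C@@]13CC(=O)[C@@](C)(CC[C@@H]21)C3` changes one group only: pyridin-2-yl in place of phenyl on an aromatic carbon. Among the measured compounds shown here, with no measured step to lean on, the expected change from compound 1 to compound 3 is a step that the limit leaves unreadable from compound 1 to compound 3, nothing beyond the scatter. Compound 3 is therefore estimated at 25000 nM, between 8000 nM and 80000 nM, most likely reported again as a limit in this assay.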

Compound 3, half-maximal inhibitory concentration: > 20000 nM
Compound 3: only a limit was reported; the forecaster's own chance of this, stated with the estimate: 85%; the middle value does not contradict the limit.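

Compound 1 and compound 3 both stop at a limit of the assay rather than a number, so no step between them can be read: the limit of > 20000 nM in this assay, at which 3 of the 3 values shown sit.

Going by these compounds, whether pyridin-2-yl in place of phenyl changes anything in this assay stays open.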